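Compound 4 against a narrow set of clearances

A few compounds are considered here, and "the series" means these few. Any claim that something is new, unique, unknown or untested is made for them only; others in the source may bear on it.

In an in vitro ADME assay on microsomes from Gut (Homo sapiens) for metabolic stability, in the presence of a further agent that is not named here (a higher number here means faster removal of the compound, a lower number slower removal), compound 1 (`CC(C)(CO)CNC(=O)c1cc2cc(C#N)ccc2n1Cc1cccc(OC(F)(F)F)c1`) gives 136 mL.min-1.g-1 and compound 2 (`COc1ccc(Br)cc1Cn1c(C(=O)NCC(C)(C)CO)cc2cc(C#N)ccc21`) gives 94 mL.min-1.g-1. Compound 3 (`Cc1ccc(Cl)cc1Cn1c(C(=O)NCC(C)(C)CO)cc2cc(C#N)ccc21`) gives 124 mL.min-1.g-1 and stands within the scatter of both. Compound 4 (`CCCOc1cccc(Cn2c(C(=O)NCC(C)(C)CO)cc3cc(C#N)ccc32)c1`) has 3-propoxyphenyl in place of 5-chloro-2-methylphenyl on a saturated chain carbon bound to an aromatic nitrogen. Going by the values given here, the one measured step at that place (a 1.3-fold higher number from compound 2 to compound 3 (0.12 log units; within the scatter)) stays within the scatter. Among the compounds with values here, no measured compound carries a propoxy group, so the expectation rests on that single step and the three close values. No step beyond the scatter is expected in this assay for this change. The expected step is small (a 1.0-fold higher number from compound 3 to compound 4 (0.00 log units; within the scatter)). Compound 4 is estimated at about the same level (middle 125 mL.min-1.g-1 with a range from 70 mL.min-1.g-1 to 220 mL.min-1.g-1).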

Compound 4, intrinsic clearance in microsomes: 45 mL.min-1.g-1
Beside the measured number, compound 4's estimate is 2.8-fold (0.44 log units) above it, outside the stated range (below it).
By their numbers in this assay, from the lowest: compound 4; then compounds 2, 3 and 1 (each within the scatter of the next).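

In this assay, going by these compounds alone, this position is the first to move the number beyond the scatter: 3-propoxyphenyl lowers it against 5-chloro-2-methylphenyl (a 2.8-fold lower number from compound 3 to compound 4 (0.44 log units; beyond the scatter)) and against 5-bromo-2-methoxyphenyl (a 2.1-fold lower number from compound 2 to compound 4 (0.32 log units; beyond the scatter)). The earlier compounds shown here stayed within the scatter of one another. Propyl in place of trifluoromethyl on the oxygen also lowers it (a 3.0-fold lower number from compound 1 to compound 4 (0.48 log units; beyond the scatter)), so a change at that oxygen alone is enough to separate compound 4 from compound 1.

An ethyl or butyl chain on that oxygen would show whether the number follows chain length. Nothing shown here explains the drop.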